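Methoxy on the anilino ring of the thiazolyl acetamide series

A few compounds are considered here, and "the series" means these few. Any claim that something is new, unique, unknown or untested is made for them only; others in the source may bear on it.

Compound 1 `Cc1nc(SCC(=O)Nc2nc(-c3ccc(Cl)cc3)cs2)n(Nc2ccccc2)c1C` is the reference point of this set. Within the data shown here, in a functional assay on OVCAR-3 cells (Homo sapiens) for antiproliferative activity, read by sulforhodamine B assay, with a stated time of 48 h (a higher number here means a weaker inhibitor of growth, a lower number a stronger inhibitor of growth), compound 1 gives 12100 nM, the only numerical value so far. Compound 2 `Cc1ccc(Nn2c(SCC(=O)Nc3nc(-c4ccccc4)cs3)nc(C)c2C)cc1` carries a methyl on the anilino ring and a plain phenyl on the thiazole, and in this assay compound 2 gives > 100000 nM, which is a limit of the assay and not a number (the limit of > 100000 nM in this assay, at which 1 of the 2 values shown sits). Among the measured compounds shown here, compound 2 differs from compound 1 in two places, so no single step can be read from that pair; the two values show only that compound 2 fell outside the measurable window while compound 1 did not.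

Compound 3 `COc1ccc(Nn2c(SCC(=O)Nc3nc(-c4ccc(Cl)cc4)cs3)nc(C)c2C)cc1` keeps the 4-chlorophenyl of compound 1 and changes the anilino group: methoxy in place of hydrogen on an aromatic carbon, so anilino becomes (4-methoxyphenyl)amino. For the measured compounds named here, no step between measured compounds covers this change. The expectation is a modest weakening, a 1.7-fold higher number from compound 1 to compound 3 (0.22 log units; within the scatter), not confidently beyond the scatter. Compound 3 is thus estimated at 20000 nM, within 7000 nM to 60000 nM.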

Compound 3, concentration for total growth inhibition: 24200 nM
The estimate for compound 3 lay 1.2-fold (0.08 log units) below the measured number, within the range that was stated.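

In this assay, among these compounds, methoxy in place of hydrogen on an aromatic carbon of the anilino ring, para to a large group, gives a 2.0-fold higher number from compound 1 to compound 3 (0.30 log units; within the scatter), the first single-place step. This substitution therefore gives no change that can be told from the scatter, and compound 3 stays inside the measurable window at 24200 nM, so this carbon accepts a methoxy without a readable loss or gain in this assay. Compound 2 remains a limit of the assay and not a number, and its differences from the other compounds span more than one place, so no step to it can be read: the limit of > 100000 nM in this assay, at which 1 of the 3 values shown sits.

The compounds shown leave open whether an amine or a carboxylic acid on this same aromatic carbon would move the number beyond the scatter from compound 1. Among the compounds shown here, no single-place pair separates the 4-chlorophenyl from the plain phenyl on the thiazole, and the part played by that chlorine therefore remains unread.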